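The source may report more compounds than this note shows. Statements on the series, on what has been measured and on what is new or still open speak of the compounds shown alone.

Compound 1 `COc1c([C@H](C)n2nc(C)c3c(N)ncnc32)cc(Cl)c(C)c1C1CNC(=O)C1`: 13 nM
Compound 2 `COc1c([C@H](C)Nc2ncnc3[nH]cnc23)cc(Cl)c(C)c1-c1ccc(S(C)(=O)=O)cc1`: 170 nM
Compound 3 `Cc1c(Cl)cc(C(C)Nc2ncnc3[nH]cnc23)c(-c2cccc(F)c2)c1-c1cnn(C)c1`: 60 nM

In a functional assay on SU-DHL-6 cells (Homo sapiens) for cytotoxicity, read by luminescence, with a stated time of 4 days (a lower number here means a stronger inhibitor, a higher number a weaker inhibitor), compound 1 gives 13 nM and compound 3 gives 60 nM, while compound 2 gives 170 nM, the highest of the three numbers; both gaps lie beyond the scatter, so compound 2 is the weakest inhibitor of the three. Compound 4 `COc1c([C@H](C)Nc2ncnc3[nH]cnc23)cc(Cl)c(C)c1-c1cncc(S(C)(=O)=O)c1` is compound 2 with a single change: 5-(methylsulfonyl)pyridin-3-yl in place of 4-(methylsulfonyl)phenyl on an aromatic carbon. No measured pair differs in just one place, so this change has no precedent among the numbers shown. The expected step is small, a 1.1-fold lower number from compound 2 to compound 4 (0.05 log units; within the scatter), most likely within the scatter, with no clear direction. Compound 4 is therefore estimated to give 150 nM in this assay, with a range from 60 nM to 400 nM.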

Compound 4, half-maximal inhibitory concentration: 14 nM
Compound 4: middle estimate off by 11-fold (1.03 log units), on the high side, outside the stated range (below it).
By their numbers in this assay, from the lowest: compounds 1 and 4 (each within the scatter of the next); then compound 3; then compound 2.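

On the aromatic carbon ortho to a methoxy group and ortho to a methyl group, replacing 4-(methylsulfonyl)phenyl with 5-(methylsulfonyl)pyridin-3-yl gives a 12-fold lower number from compound 2 to compound 4 (1.08 log units; beyond the scatter) in this assay and shows that this position is sensitive to the ring it carries. The two groups have the same heavy-atom count, yet the large step comes with a ring nitrogen, an added hydrogen-bond acceptor and a different numbering of the methylsulfonyl group.

As far as these compounds go, whether a pyridin-3-yl ring carrying an amine instead of methylsulfonyl would keep this gain remains open. No measurement shown explains the step.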